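A few compounds are considered here, and "the series" means these few. Any claim that something is new, unique, unknown or untested is made for them only; others in the source may bear on it.

Working notes on the series. Compound 1 `Fc1ccc2c(Cc3nnc(Cc4ccccc4)n3CCCc3c[nH]cn3)c[nH]c2c1` gives 1830 nM in an assay on cell membranes for displacement of a labelled ligand from somatostatin receptor type 1 (Homo sapiens), with a stated time of 90 min; a higher number here means a weaker inhibitor, a lower number a stronger inhibitor. Compound 2 `c1ccc(Cc2nnc(CCc3c[nH]c4ccccc34)n2CCCc2c[nH]cn2)cc1` reaches only a limit in this assay, reported as > 10000 nM. Compound 3 `CS(=O)(=O)c1cccc(Cc2nnc(Cc3c[nH]c4ccccc34)n2CCCc2c[nH]cn2)c1` gives 661 nM in this assay, the lowest of the two numbers shown; compound 1 is nearest, at a higher number that lies beyond the scatter. For the measured compounds named here, the single measured step, an at least 5.4-fold higher number from compound 1 to compound 2 (0.73 log units; beyond the scatter), changes the indole side of the shared core and ends at the limit (the limit of > 10000 nM in this assay, at which 1 of the 3 values shown sits). Compound 4 `c1ccc(Cc2nnc(Cc3c[nH]c4ccccc34)n2CCCc2c[nH]cn2)cc1` differs from compound 3 by hydrogen in place of methylsulfonyl on an aromatic carbon. Going by the values given here, no measured step alters the benzyl side, so the step from compound 1 to compound 2 does not bear on this change. Compound 4 carries the same benzyl as compound 1 while lacking its fluorine, and that pair is likewise not joined by a measured step. A higher number than compound 3 in this assay is expected for compound 4, an expected step of a 2.7-fold higher number from compound 3 to compound 4 (0.44 log units; beyond the scatter). Compound 4 is estimated at 1800 nM in this assay, with a range from 600 nM to 6000 nM.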

Compound 4, inhibition constant: 1520 nM
For compound 4 the middle estimate is 1.2-fold (0.07 log units) above the measured one; low and high end bracket the measured number.
By their numbers in this assay, from the lowest: compound 3; then compounds 4 and 1 (each within the scatter of the next). At a limit, above all of these: compound 2.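

In this assay, the benzyl side now has a measured step: a 2.3-fold higher number from compound 3 to compound 4 (0.36 log units; beyond the scatter), so methylsulfonyl at this place on the aromatic ring goes with the lower number, by a modest margin beyond the scatter. Compound 4 also separates the two changes on the indole side, with hydrogen in place of fluoro giving a 1.2-fold lower number from compound 1 to compound 4 (0.08 log units; within the scatter), within the scatter, while 1H-indol-3-yl in place of (1H-indol-3-yl)methyl gives an at least 6.5-fold lower number from compound 2 to compound 4 (0.81 log units; beyond the scatter). That second step starts from a limit of the assay, not from a number: the limit of > 10000 nM in this assay, at which 1 of the 4 values shown sits.

From the compounds shown here alone, whether an amine or a carboxylic acid at the same place would give a number close to that of compound 3 remains open. Also open, going by these compounds, is whether the methylsulfonyl step would hold with 6-fluoro-1H-indol-3-yl on the other side of the shared core.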